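A Further Methoxy Group and What to Expect of It

The source may report more compounds than this note shows. Statements on the series, on what has been measured and on what is new or still open speak of the compounds shown alone.

Compound 1 `COc1ccc(-c2cc(/C=C/C(=O)c3ccc(N)cc3)[nH]n2)cc1` and compound 3 `COc1ccc(-c2cc(/C=C/C(=O)c3ccc(N)cc3)[nH]n2)cc1OC` share one core and differ in a single place. In a functional assay on KM12 cells (Homo sapiens) for cytotoxicity, read by sulforhodamine B assay, with a stated time of 48 h, tested at 100 uM (on this read-out higher numbers stand for a weaker effect at the one concentration tested and lower numbers for a stronger effect), compound 1 gives -78%, while compound 3 gives -98%. The change between them, (methoxy in place of hydrogen on an aromatic carbon), produced a number 20 percentage points lower from compound 1 to compound 3 (beyond the scatter). Compound 2 `COc1ccc(C(=O)/C=C/c2cc(-c3cc(OC)c(OC)c(OC)c3)n[nH]2)cc1OC` is built on a different core; how the two cores differ is not broken down here. In this assay compound 2 gives -75%, which lies within the usual scatter of the value of compound 1, whereas the value of compound 3 lies beyond that scatter from both. Compound 4 `COc1cc(C(=O)/C=C/c2cc(-c3cc(OC)c(OC)c(OC)c3)n[nH]2)cc(OC)c1OC` has not yet been measured and differs from compound 2 by methoxy in place of hydrogen on an aromatic carbon. Within the data shown here, the place in compound 4 is also meta to a methoxy group, so this is the same kind of change as the one from compound 1 to compound 3, not the same. Because a number 20 percentage points lower from compound 1 to compound 3 (beyond the scatter) was a modest step, a step of similar size is expected here, namely a number 17 percentage points lower from compound 2 to compound 4 (beyond the scatter) in this assay. Compound 4 is therefore estimated to give -92%, plausibly between -105% and -72%.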

Compound 4, a percentage reported as activity, at one concentration (the size of the read-out at that concentration, not a potency): -81%
Compound 4: the middle estimate sits 11 percentage points below what was measured; the range from low to high includes it.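

In this assay, methoxy in place of hydrogen on the core of compound 2 gave a number 6 percentage points lower from compound 2 to compound 4 (within the scatter), a step that by itself cannot be told apart from the scatter of repeated measurements. Set beside the earlier step on the other core, this step does not differ from it by more than such scatter allows: the same change on two cores in this assay, a number 20 percentage points lower (beyond the scatter) from compound 1 to compound 3 and a number 6 percentage points lower (within the scatter) from compound 2 to compound 4, 14 percentage points apart, within the scatter of two such steps

Among these compounds, the result is therefore compatible with the change carrying over from one core to the other, but it does not prove this: only one of the two steps stands clear of the scatter, and two pairs cannot fix a general size for the step.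

The compounds shown leave open whether a longer chain such as ethoxy, or a chlorine atom, at the same place would act as methoxy does. Also open, from the compounds shown here alone, is whether these compounds would show a stronger or weaker effect at any other concentration, as the read-out gives only the size of an effect at a single concentration.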